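The source may hold more compounds than are shown below. What is called first, only, known or untested is meant among the compounds shown, and "the series" means these compounds.

Measured compounds in an assay on isolated protein for inhibition of histone deacetylase 8 (Homo sapiens), with a stated time of 1 h; on this read-out lower numbers stand for stronger inhibition and higher numbers for weaker inhibition:

- compound 1 `Cc1ccc(NC(=O)COc2ccc3cc(/C=C4/SC(=O)NC4=O)ccc3c2)cc1`: 9000 nM
- compound 2 `O=C(COc1ccc2cc(/C=C3/SC(=O)NC3=O)ccc2c1)Nc1ccc(Cl)c(Cl)c1`: the assay reports only a limit, > 50000 nM
- compound 3 `Cc1cccc(NC(=O)COc2ccc3cc(/C=C4/SC(=O)NC4=O)ccc3c2)n1`: 7500 nM

Compound 1 stands highest of the two numbers given; compound 3 sits within the scatter of it, a 1.2-fold lower number from compound 1 to compound 3 (0.08 log units; within the scatter). Compound 2 gives a limit and no number (the limit of > 50000 nM in this assay, at which 1 of the 3 values shown sits). Among the compounds with values here, the move to 3,4-dichlorophenyl is the only step beyond the scatter, an at least 5.5-fold higher number from compound 1 to compound 2 (0.74 log units; beyond the scatter), and the same reading holds for an at least 6.6-fold lower number from compound 2 to compound 3 (0.82 log units; beyond the scatter).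

Compound 4 `Cc1cc(NC(=O)COc2ccc3cc(/C=C4/SC(=O)NC4=O)ccc3c2)no1` differs from compound 1 in one place: 5-methyl-1,2-oxazol-3-yl in place of 4-methylphenyl on an amide-type nitrogen. The step that bears most on it is the swap of 4-methylphenyl for another aromatic ring carrying hetero atoms, a 1.2-fold lower number from compound 1 to compound 3 (0.08 log units; within the scatter), which stayed within the scatter; the dichlorophenyl step is of a different kind and is not taken as a guide here. No step beyond the scatter is therefore expected, no change at the digits printed from compound 1 to compound 4 (within the scatter). For compound 4 in this assay the estimate is 9000 nM, expected to fall between 3000 nM and 30000 nM.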

Compound 4, half-maximal inhibitory concentration: > 50000 nM
Compound 4: only a limit was reported (the forecaster's own chance of this, stated with the estimate: 15%); middle value at least 5.5-fold (0.74 log units) away from the limit.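

At the amide-type nitrogen, the ring cannot be exchanged freely in this assay: the swap to 5-methyl-1,2-oxazol-3-yl gives an at least 5.5-fold higher number from compound 1 to compound 4 (0.74 log units; beyond the scatter), and also an at least 6.6-fold higher number from compound 3 to compound 4 (0.82 log units; beyond the scatter). A ring carrying hetero atoms therefore does not settle the outcome on its own, as compound 3 stays within the scatter of compound 1 while compound 4 does not. Compound 4 gives only a limit, the same one as compound 2: the limit of > 50000 nM in this assay, at which 2 of the 4 values shown sit.

The step between compound 2 and compound 4 cannot be read, and neither compound can be ranked against the other. As far as these compounds go, it remains open whether the five-membered ring itself or the arrangement of its hetero atoms goes with the weaker result, and how an amine or a carboxylic acid on the ring at this nitrogen would read.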